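Carbonyl-linked pyrazole on the biphenyl-type sulfonylcarbamate scaffold

This account rests on a few compounds, and the source may have more. Where it says the series, first, only, none or still open, it means among the compounds named here.

Measured compounds:
Compound 1 `CCCCOC(=O)NS(=O)(=O)c1sc(CC(C)C)cc1-c1ccc(CN2CCN(C)C2=O)cc1`: 16.5 nM
Compound 2 `CCCCOC(=O)NS(=O)(=O)c1sc(CC(C)C)cc1-c1ccc(C(=O)c2ncco2)cc1`: 13.8 nM
Compound 3 `CCCCOC(=O)NS(=O)(=O)c1sc(CC(C)C)cc1-c1ccc(Cc2ncco2)cc1`: 3.9 nM

In an assay on membranes from uterus for displacement of a labelled ligand from Angiotensin type II receptor (Sus scrofa), with a stated time of 1.5 h (on this read-out higher numbers stand for weaker inhibition and lower numbers for stronger inhibition), compound 1 gives the highest of the three numbers. Compound 2 is nearest to it, a 1.2-fold lower number from compound 1 to compound 2 (0.08 log units; within the scatter), while compound 3 is furthest, a 4.2-fold lower number from compound 1 to compound 3 (0.63 log units; beyond the scatter). Between the two oxazole compounds, a 3.5-fold lower number from compound 2 to compound 3 (0.55 log units; beyond the scatter), so a methyl link to the five-membered aromatic ring gave a lower number than a carbonyl link.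

Compound 4 `CCCCOC(=O)NS(=O)(=O)c1sc(CC(C)C)cc1-c1ccc(C(=O)c2ccnn2C)cc1` differs from compound 1 in one place: (1-methyl-1H-pyrazol-5-yl)carbonyl in place of (3-methyl-2-oxoimidazolidin-1-yl)methyl on an aromatic carbon. The step from compound 1 to compound 2 is the closest model, since there too a carbonyl-linked five-membered aromatic ring replaced the saturated ring on a methyl; that step stayed within the scatter. The step from compound 2 to compound 3 suggests that the carbonyl link, rather than a methyl link, is the less favourable of the two. Compound 4 is therefore expected to sit close to compound 1, with a 1.2-fold lower number from compound 1 to compound 4 (0.07 log units; within the scatter) not beyond the scatter. For compound 4 the estimate in this assay is 14 nM, within a range of 6 nM to 32 nM.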

Compound 4, inhibition constant: 3.4 nM
Compound 4: the middle estimate sits 4.1-fold (0.61 log units) above what was measured, and the stated range ends above it.
By their numbers in this assay, from the lowest: compounds 4 and 3 (each within the scatter of the next); then compounds 2 and 1 (each within the scatter of the next).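

In this assay, the carbonyl link on this aromatic carbon, para to a large group, does not by itself hold the number up: changing only the ring on the carbonyl carbon, from 1,3-oxazol-2-yl to 1-methyl-1H-pyrazol-5-yl, gives (a 4.1-fold lower number from compound 2 to compound 4 (0.61 log units; beyond the scatter)). Unlike the oxazole ketone, the pyrazole ketone therefore also departs from the (3-methyl-2-oxoimidazolidin-1-yl)methyl compound (a 4.9-fold lower number from compound 1 to compound 4 (0.69 log units; beyond the scatter)). It also stands level with the methyl-linked oxazole (a 1.1-fold lower number from compound 3 to compound 4 (0.06 log units; within the scatter)), so the earlier disadvantage of the carbonyl link held for the oxazole pair but does not extend to every ring. No measurement at hand explains these differences. Still open, as far as these compounds go, is whether a methylene link would serve the 1-methyl-1H-pyrazol-5-yl ring as well, and how a longer chain in place of its methyl, or an amine on the ring, would read in this assay.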